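Bromobenzoyl indolyl benzimidazoles: growth inhibition working notes

This account rests on a few compounds, and the source may have more. Where it says the series, first, only, none or still open, it means among the compounds named here.

Compound 1 `Cn1cc(-c2nc3ccccc3n2C(=O)c2ccccc2Br)c2ccccc21` carries a (2-bromophenyl)carbonyl on the shared core; in a functional assay on A549 cells (Homo sapiens) for inhibition, read by MTT assay, with a stated time of 24 h (a higher number here means a weaker inhibitor of growth, a lower number a stronger inhibitor of growth), compound 1 gives 43200 nM. Compound 2 `Cn1cc(-c2nc3ccccc3n2C(=O)c2cccc(Br)c2)c2ccccc21` differs from compound 1 by 3-bromophenyl in place of 2-bromophenyl on a carbonyl carbon, and in this assay compound 2 gives 34200 nM; the step is a 1.3-fold lower number from compound 1 to compound 2 (0.10 log units; within the scatter). Compound 3 `Cn1cc(-c2nc3ccccc3n2C(=O)c2ccccc2Br)c2cc(Br)ccc21` differs from compound 1 by bromo in place of hydrogen on an aromatic carbon; in this assay compound 3 gives 46700 nM, a step of a 1.1-fold higher number from compound 1 to compound 3 (0.03 log units; within the scatter). Compound 4 `Cn1cc(-c2nc3ccccc3n2C(=O)c2cccc(Br)c2)c2cc(Br)ccc21` has not yet been measured in this assay. It differs from compound 3 by 3-bromophenyl in place of 2-bromophenyl on a carbonyl carbon, the same change already made from compound 1 to compound 2, at an identically described place. None of the three measured compounds moves the read-out beyond the usual scatter. The step to compound 4 is therefore expected to be a 1.3-fold lower number from compound 3 to compound 4 (0.10 log units; within the scatter), resting on the earlier step of a 1.3-fold lower number from compound 1 to compound 2 (0.10 log units; within the scatter). Compound 4 is estimated at 37000 nM, between 20000 nM and 70000 nM.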

Compound 4, concentration for 50% growth inhibition: 38500 nM
Compound 4: middle estimate off by 1.0-fold (0.02 log units), on the low side, and the stated range covers the measured number.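

The change from 2-bromophenyl to 3-bromophenyl on the carbonyl carbon, made on the brominated core, gives a 1.2-fold lower number from compound 3 to compound 4 (0.08 log units; within the scatter) in this assay, and it matches the earlier step: the same change on two cores in this assay, a 1.3-fold lower number (0.10 log units; within the scatter) from compound 1 to compound 2 and a 1.2-fold lower number (0.08 log units; within the scatter) from compound 3 to compound 4, 1.0-fold (0.02 log units) apart, within the scatter of two such steps

Bromo in place of hydrogen on an aromatic carbon, made on the 3-bromophenyl compound, gives a 1.1-fold higher number from compound 2 to compound 4 (0.05 log units; within the scatter), and it also matches the earlier step: the same change on two cores in this assay, a 1.1-fold higher number (0.03 log units; within the scatter) from compound 1 to compound 3 and a 1.1-fold higher number (0.05 log units; within the scatter) from compound 2 to compound 4, 1.0-fold (0.02 log units) apart, within the scatter of two such steps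

For the compounds shown here, all of these steps lie within the scatter, so the agreement shows only that neither change shifts the read-out on these cores, not that a measurable effect carries from one core to another.

Left open is whether a group other than bromo on the phenyl ring, such as an amine or a carboxylic acid, would move the number beyond the scatter in this assay. Also open, on these data alone, is whether a longer chain in place of the methyl on the shared core would do so.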